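The source may report more compounds than this note shows. Statements on the series, on what has been measured and on what is new or still open speak of the compounds shown alone.

In a functional assay on SK-OV-3 cells (Homo sapiens) for cytotoxicity (a higher number here means a weaker inhibitor of growth, a lower number a stronger inhibitor of growth), compound 2 `COc1ccc(C2=C(c3ccc(SC)cc3)CC3CCCN3C2=O)cc1` gives 3000 nM, level with compound 1 `COc1ccc(C2=C(c3ccc(SC)cc3)CC3CCCN3C2=O)cc1Br`, which gives 3000 nM. Compound 3 `CSc1ccc(C2=C(c3ccc(F)cc3)C(=O)N3CCCC3C2)cc1` carries fluoro in place of methoxy on an aromatic carbon, para to a large group: fluoro in place of methoxy on an aromatic carbon. Among the measured compounds shown here, the only measured step, hydrogen in place of bromo, shows no change at the digits printed from compound 1 to compound 2 (within the scatter). For the measured compounds named here, that step leaves the methoxy untouched, so it offers only weak guidance here, and no measured step tests this swap directly. The expected step is small, leaning towards weaker growth inhibition: a 1.5-fold higher number from compound 2 to compound 3 (0.18 log units; within the scatter). For compound 3 the estimated value is 4500 nM, with a range of 1500 nM to 15000 nM.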

Compound 3, concentration for 50% growth inhibition: 30000 nM
The estimate for compound 3 lay 6.7-fold (0.82 log units) below the measured number, outside the stated range (above it).
By their numbers in this assay, from the lowest: compounds 1 and 2 (each within the scatter of the next); then compound 3.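

In this assay the methoxy place proves sensitive in a way the bromo place did not: fluoro in place of methoxy gives a 10-fold higher number from compound 2 to compound 3 (1.00 log units; beyond the scatter) and so weaker growth inhibition. Putting 4-fluorophenyl in place of 3-bromo-4-methoxyphenyl gives a 10-fold higher number from compound 1 to compound 3 (1.00 log units; beyond the scatter) as well, so the loss is the same size whether or not the starting compound carries bromo. Nothing available explains this loss.

Still open, from the compounds shown here alone, is whether the methoxy itself is special. Ethoxy, hydroxy or an amine at this place could keep the growth inhibition or lose it as fluoro does.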